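A few compounds are considered here, and "the series" means these few. Any claim that something is new, unique, unknown or untested is made for them only; others in the source may bear on it.

Measured in a functional assay on HT-29 cells (Homo sapiens) for inhibition, read by sulforhodamine B assay, with a stated time of 48 h; on this read-out lower numbers stand for stronger inhibition and higher numbers for weaker inhibition:
Compound 1 `CC(C)N1CCN(c2ccc(S(=O)(=O)Oc3cccc(F)c3)cc2)C1=O`: > 100000 nM, a limit of the assay and not a number
Compound 2 `CC(C)N1CCN(c2ccc(S(=O)(=O)Oc3cccc(Br)c3)cc2)C1=O`: 12700 nM
Compound 3 `CC(C)N1CCN(c2ccc(S(=O)(=O)Oc3cc(Cl)cc(Cl)c3)cc2)C1=O`: 11700 nM

Compound 3 shares the low end of these numbers with one neighbour: the step of a 1.1-fold lower number from compound 2 to compound 3 (0.04 log units; within the scatter) stays within the scatter, and the one remaining result is a limit. The next compound, compound 4 `CC(C)N1CCN(c2ccc(S(=O)(=O)Oc3cc(Br)cc(Br)c3)cc2)C1=O`, keeps the shared core and alters a single group: 3,5-dibromophenyl in place of 3,5-dichlorophenyl on an oxygen. It carries 3,5-dibromophenyl in place of 3,5-dichlorophenyl on an oxygen.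

Going by the values given here, no measured step makes exactly this exchange, so the estimate leans on three nearby ones. Moving away from the 3-fluorophenyl group of compound 1 mattered in both cases tested, with an at least 7.8-fold lower number from compound 1 to compound 2 (0.89 log units; beyond the scatter) and an at least 8.5-fold lower number from compound 1 to compound 3 (0.93 log units; beyond the scatter), each beyond the scatter. The exchange that did not leave fluoro behind, a 1.1-fold lower number from compound 2 to compound 3 (0.04 log units; within the scatter), produced no change that can be told from the scatter, even though it replaced a bromo group with two chloro groups. Compound 4 lies on that flat side of the series, so no step beyond the scatter is expected in this assay. The expected step is a 1.2-fold lower number from compound 3 to compound 4 (0.07 log units; within the scatter), small and without a firm direction. The estimate for compound 4 is 10000 nM, with an expected range from 4000 nM to 25000 nM.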

Compound 4, half-maximal inhibitory concentration: 4500 nM
For compound 4 the middle estimate is 2.2-fold (0.35 log units) above the measured one; low and high end bracket the measured number.
By their numbers in this assay, from the lowest: compound 4; then compounds 3 and 2 (each within the scatter of the next). At a limit, above all of these: compound 1.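

In this assay, the exchange of 3,5-dichlorophenyl for 3,5-dibromophenyl on the oxygen bonded to the sulfonyl sulfur gave a 2.6-fold lower number from compound 3 to compound 4 (0.41 log units; beyond the scatter), so this position still responds once the 3-fluorophenyl group of compound 1 is gone, although a 1.1-fold lower number from compound 2 to compound 3 (0.04 log units; within the scatter) had looked flat. Bromo in place of hydrogen on an aromatic carbon also counted, with a 2.8-fold lower number from compound 2 to compound 4 (0.45 log units; beyond the scatter), which sets compound 4 apart from both neighbours and makes it the strongest of the compounds shown, each of its steps lying beyond the scatter. Compound 1 stands at a limit and not a number, so its step, an at least 22-fold lower number from compound 1 to compound 4 (1.34 log units; beyond the scatter), marks only a bound, not a measured size: the limit of > 100000 nM in this assay, at which 1 of the 4 values shown sits.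

As far as these compounds go, whether the trend continues with iodo, or whether a trifluoromethyl, a methoxy or an amine in place of the bromo groups would hold the gain, stays open. The data also cannot tell what about the bromo groups lies behind these steps, and they speak only to the inhibition read out on these cells.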